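The source may report more compounds than this note shows. Statements on the series, on what has been measured and on what is new or still open speak of the compounds shown alone.

Measured so far in a functional assay on HOS cells (Homo sapiens) for inhibition, with a stated time of 72 h; on this read-out higher numbers stand for weaker inhibition and lower numbers for stronger inhibition:
- compound 1 `COc1ccccc1-c1ccc(CNc2nc(NC3CCC(N)CC3)nc3c2ncn3C2CCCC2)cc1`: 150 nM
- compound 2 `NC1CCC(Nc2nc(NCc3ccc(-c4ccsc4)cc3)c3ncn(C4CCCC4)c3n2)CC1`: 120 nM
- compound 3 `CC(C)(O)CNc1nc(NCc2ccc(-c3ccco3)cc2)c2ncn(C3CCCC3)c2n1`: 21400 nM

Compound 2, at 120 nM, lies within the scatter of compound 1, at 150 nM. Together they sit at the low end of the numbers, while compound 3 shows a far higher 21400 nM.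

Compound 4 `NC1CCC(Nc2nc(NCc3ccc(-c4cccs4)nc3)c3ncn(C4CCCC4)c3n2)CC1` differs from compound 2 in one place: 6-(thiophen-2-yl)pyridin-3-yl in place of 4-(thiophen-3-yl)phenyl on a saturated chain carbon bound to a nitrogen on an aromatic ring. In words, 6-(thiophen-2-yl)pyridin-3-yl stands in place of 4-(thiophen-3-yl)phenyl on a saturated chain carbon bound to a nitrogen on an aromatic ring.

For the measured compounds named here, one measured step bears on this. Thiophen-3-yl in place of 2-methoxyphenyl on an aromatic carbon gave a 1.3-fold lower number from compound 1 to compound 2 (0.10 log units; within the scatter), so that outer group could be exchanged without a clear shift. Going by the values given here, no measured compound tests a hetero atom in the six-membered aromatic ring, so the forecast is uncertain.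

The expected result is a 1.3-fold higher number from compound 2 to compound 4 (0.10 log units; within the scatter), which would be no step beyond the scatter. For compound 4 the estimated value is 150 nM, with an expected range of 50 nM to 500 nM.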

Compound 4, half-maximal inhibitory concentration: 32 nM
Beside the measured number, compound 4's estimate is 4.7-fold (0.67 log units) above it; the whole stated range lies above it.
By their numbers in this assay, from the lowest: compound 4; then compounds 2 and 1 (each within the scatter of the next); then compound 3.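

In this assay, the group on a saturated chain carbon bound to a nitrogen on an aromatic ring proves able to shift the result: placing 6-(thiophen-2-yl)pyridin-3-yl in place of 4-(thiophen-3-yl)phenyl gave a 3.8-fold lower number from compound 2 to compound 4 (0.57 log units; beyond the scatter) and so a step beyond the scatter. The earlier exchange of the outer group alone gave only a 1.3-fold lower number from compound 1 to compound 2 (0.10 log units; within the scatter) and did not show this. No measured evidence here explains the drop.

This change also alters two things at once, a nitrogen in the six-membered aromatic ring and the point at which the thiophene is attached, so the step cannot be assigned to either one. Compounds bearing 4-(thiophen-2-yl)phenyl or 6-(thiophen-3-yl)pyridin-3-yl at this place would separate the two.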